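Fluoro in place of methoxy on the core of compound 2

The compounds below may be only part of what the source reports. "The series", "measured", "known", "first", "only" and "open" are said of these compounds alone.

Compound 1, `COc1ccc(-c2cn3ccnc3c(-c3ccc4ncn(C5CCCCC5)c4c3)n2)cc1`: 71.2%
Compound 2, `COc1ccccc1-c1cn2ccnc2c(-c2ccc3ncn(C4CCCCC4)c3c2)n1`: 8.78%

Both measured compounds share one core and were tested in a functional assay on OVCAR-8 cells (Homo sapiens) for inhibition, read by sulforhodamine B assay, with a stated time of 48 h, tested at 10 uM; a lower number here means less inhibition, a higher number more inhibition at the concentration tested (going by the name of the read-out). Compound 1 gives 71.2%, while compound 2 gives 8.78%, the lowest of the two numbers. Among the measured compounds shown here, the single measured step, a number 62.4 percentage points lower from compound 1 to compound 2 (beyond the scatter), comes from moving the methoxy group from one aromatic carbon to another.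

Compound 3, `Fc1ccccc1-c1cn2ccnc2c(-c2ccc3ncn(C4CCCCC4)c3c2)n1`, is not yet measured. It differs from compound 2 in one place: fluoro in place of methoxy on an aromatic carbon. For the measured compounds named here, no measured step replaces a methoxy group with fluoro, so the only step available does not bear on this change directly; it shows only that the position of a group on that ring matters strongly, not what happens when the group itself is exchanged at a fixed position. With no guide beyond the starting point of compound 2, the expected step is none beyond the scatter: a number 3.2 percentage points higher from compound 2 to compound 3 (within the scatter) is the estimate for the move. Compound 3 is therefore expected to give about 12% in this assay, within a range from 0% to 35%.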

Compound 3, a percentage reported as inhibition, at one concentration (the size of the read-out at that concentration, not a potency): 14.1%
Compound 3: middle estimate off by 2.1 percentage points, on the low side, and the stated range covers the measured number.
By their numbers in this assay, from the lowest: compounds 2 and 3 (each within the scatter of the next); then compound 1.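

In this assay, the exchange on the aromatic carbon ortho to a large group gives a number 5.3 percentage points higher from compound 2 to compound 3 (within the scatter), so compound 2 and compound 3 cannot be told apart, even though fluoro is a single heavy atom and methoxy has two. With 2-fluorophenyl in place of 4-methoxyphenyl, the result is a number 57.1 percentage points lower from compound 1 to compound 3 (beyond the scatter), which means that two different groups at this place, the methoxy of compound 2 and the fluoro of compound 3, both give far less inhibition than compound 1 at the concentration tested, and the low number at this place is not peculiar to methoxy. Nothing measured here gives a reason for these numbers.

The step to compound 3 exchanges the group and moves it at once, so the compounds shown leave open what fluoro would give at the place where compound 1 carries its methoxy. From the compounds shown here alone, it also remains open whether an amine or a carboxylic acid on the carbon ortho to a large group would give a number as low as those of compound 2 and compound 3, or one closer to that of compound 1.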